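A few compounds are considered here, and "the series" means these few. Any claim that something is new, unique, unknown or untested is made for them only; others in the source may bear on it.

Measured compounds in this set:
compound 1 `N#Cc1ccc(Nc2nccc(OCc3ccccc3F)n2)cc1` — 151000 nM
compound 2 `N#Cc1ccc(Nc2nccc(OCc3ccccc3C(F)(F)F)n2)cc1` — 173000 nM
compound 3 `COc1cc(COc2ccnc(Nc3ccc(C#N)cc3)n2)cc(OC)c1` — 44200 nM

All three numbers come from an ADME assay on MT4 cells (Homo sapiens) for cytotoxicity, read by MTT assay, with a stated time of 5 days; on this read-out lower numbers stand for higher toxicity in this test and higher numbers for lower toxicity in this test. Compound 1 stands second highest of the three. Its nearest neighbour is compound 2: the step of a 1.1-fold higher number from compound 1 to compound 2 (0.06 log units; within the scatter) lies within the scatter. For the measured compounds named here, its furthest neighbour is compound 3, whose number is lower than that of compound 1 by a gap beyond the scatter; the two differ in more than one place, so no single step connects them.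

Compound 4 `N#Cc1ccc(Nc2nccc(OCc3cc(F)ccc3Br)n2)cc1` has not been measured. Relative to compound 1 the change is 2-bromo-5-fluorophenyl in place of 2-fluorophenyl on a saturated chain carbon bound to an oxygen on an aromatic ring. Going by the values given here, the only measured step that bears on it is the one from compound 1 to compound 2, also a change of substituent on the same aromatic ring, and that step stayed within the scatter. Nothing measured separates the effect of adding a bromine from the effect of moving the fluorine. On this basis no step beyond the scatter is expected in this assay for compound 4, with the value of compound 3 kept in view as a reminder that a differently substituted ring at this position can give a lower number.

Compound 4 is therefore expected to give 130000 nM, within a range of 50000 nM to 300000 nM. The estimated step from compound 1 to compound 4 is a 1.2-fold lower number from compound 1 to compound 4 (0.07 log units; within the scatter).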

Compound 4, half-maximal cytotoxic concentration: 190000 nM
Beside the measured number, compound 4's estimate is 1.5-fold (0.16 log units) below it; the range from low to high includes it.
By their numbers in this assay, from the lowest: compound 3; then compounds 1, 2 and 4 (each within the scatter of the next).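

In this assay, 2-bromo-5-fluorophenyl in place of 2-fluorophenyl on a saturated chain carbon bound to an oxygen on an aromatic ring gives a 1.3-fold higher number from compound 1 to compound 4 (0.10 log units; within the scatter) and so stays within the scatter, which shows that this position accepts a ring carrying a bromine as well as a fluorine without a measurable shift in the number. With a 1.1-fold higher number from compound 1 to compound 2 (0.06 log units; within the scatter) also within the scatter, two different substituent changes on this ring now leave the read-out unmoved, although here the entering group has 8 heavy atoms against 7 in the group that leaves. Nothing available explains why the number holds steady across these changes.

The separate contributions of the bromine and of the altered fluorine placement remain unresolved, as this single step carries both together. Also open, as far as these compounds go, is whether an amine or a carboxylic acid on this ring, or a longer chain at this position, would likewise leave the number within the scatter in this assay or would instead produce a real step.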